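Series notes: furan-2-yl for 4-methoxyphenyl, second instance

A few compounds are considered here, and "the series" means these few. Any claim that something is new, unique, unknown or untested is made for them only; others in the source may bear on it.

Measured compounds:
Compound 1 `COc1ccc(/C=C/C(=O)c2ccc(NC(=O)C(C)O[N+](=O)[O-])cc2)cc1` gives 50% in a functional assay on the whole organism (strain albino) for inhibition, with Rattus norvegicus as the target, read by paw edema, with stated times of 30 min and 3 h, at a dose of 100 mg/kg by the oral route; a lower number here means less inhibition, a higher number more inhibition at the dose given (going by the name of the read-out).
Compound 2 `CC(O[N+](=O)[O-])C(=O)Nc1ccc(C(=O)/C=C/c2ccco2)cc1` gives 54% in this assay.
Compound 3 `COc1ccc(/C=C/C(=O)c2ccc(NC(=O)COc3ccc(C(C)=O)cc3)cc2)cc1` gives 42% in this assay.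

Compound 4 `CC(=O)c1ccc(OCC(=O)Nc2ccc(C(=O)/C=C/c3ccco3)cc2)cc1` is not yet measured in this assay.

Compound 3 and compound 4 differ in one place: furan-2-yl in place of 4-methoxyphenyl on a double-bonded chain carbon bound to a double-bonded chain carbon. The same change has been measured once already, between compound 1 and compound 2: furan-2-yl in place of 4-methoxyphenyl on a double-bonded chain carbon bound to a double-bonded chain carbon. Both place descriptions read alike word for word, so the change is the same, made on two different cores. How the core of compound 1 and the core of compound 3 differ is not broken down here. The measured step for the first pair is a number 4 percentage points higher from compound 1 to compound 2 (within the scatter). Compound 3 and compound 1 lie within the scatter of each other; compound 3 and compound 2 lie beyond it.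

For compound 4 the expectation rests on a single measured instance of the change, on the other core, where the step from compound 1 to compound 2 was a number 4 percentage points higher from compound 1 to compound 2 (within the scatter). A step of similar size is therefore expected from compound 3 to compound 4 in this assay, namely a number 4 percentage points higher from compound 3 to compound 4 (within the scatter). Compound 4 is estimated at 46% in this assay. Within the data shown here, the expected range for compound 4 runs from 35% to 57%, wide because only one pair, compound 1 to compound 2, a number 4 percentage points higher from compound 1 to compound 2 (within the scatter), supports the transfer.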

Compound 4, a percentage reported as inhibition, in the whole organism at one dose (the size of the read-out at that dose, not a potency): 45%
Compound 4: the middle estimate sits 1 percentage points above what was measured, and the stated range covers the measured number.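

In this assay, placing furan-2-yl in place of 4-methoxyphenyl on a double-bonded chain carbon bound to a double-bonded chain carbon gives a number 3 percentage points higher from compound 3 to compound 4 (within the scatter), and this second instance agrees with the first: the same change on two cores in this assay, a number 4 percentage points higher (within the scatter) from compound 1 to compound 2 and a number 3 percentage points higher (within the scatter) from compound 3 to compound 4, 1 percentage points apart, within the scatter of two such steps. For the two cores shown, the change can therefore be carried from one to the other with the step read on one core serving as a fair guide to the step on the other. This does not show that furan-2-yl and 4-methoxyphenyl differ in this read-out, since both steps lie within the scatter, and two small steps cannot show how the change would behave on a further core, or whether a larger step would carry over equally well; the read-out is also taken at a single dose and is no measure of potency.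

Open, going by these compounds, is whether another group on the same chain carbon, such as thiophen-2-yl or a phenyl ring carrying a dimethylamino group, would give a step beyond the scatter on either core. Also open, on these data alone, is whether the agreement would hold on a third core, for instance one bearing a carboxylic acid.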